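The source may report more compounds than this note shows. Statements on the series, on what has been measured and on what is new or still open speak of the compounds shown alone.

Compound 1, `O=C(Nc1ccc(Oc2ccnc3[nH]ccc23)c(F)c1)c1cn(-c2ccc(F)cc2)c2ccccc2c1=O`: in a functional assay on A549 cells (Homo sapiens) for inhibition, read by MTT assay, with a stated time of 72 h (on this read-out higher numbers stand for weaker inhibition and lower numbers for stronger inhibition), compound 1 gives 290 nM.
Compound 2, `O=C(Nc1ccc(Oc2ccnc3[nH]ccc23)c(F)c1)c1cn(-c2ccc(Br)cc2)c2ccccc2c1=O`: in this assay compound 2 gives 950 nM.
Compound 3, `O=C(Nc1ccc(Oc2ccnc3[nH]ccc23)c(F)c1)c1cn(-c2ccc(Br)cc2F)c2ccccc2c1=O`: in this assay compound 3 gives 1150 nM.

Among these three, compound 3 carries the highest number in this assay. Its nearest neighbour is compound 2, and the step of a 1.2-fold higher number from compound 2 to compound 3 (0.08 log units; within the scatter) lies within the scatter, so the two cannot be ordered. The furthest is compound 1, with the step of a 4.0-fold higher number from compound 1 to compound 3 (0.60 log units; beyond the scatter) beyond the scatter.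

Compound 4, `COc1ccc(-n2cc(C(=O)Nc3ccc(Oc4ccnc5[nH]ccc45)c(F)c3)c(=O)c3ccccc32)cc1`, differs from compound 3 in one place: 4-methoxyphenyl in place of 4-bromo-2-fluorophenyl on an aromatic nitrogen. For the measured compounds named here, two measured steps bear on this position. The step of a 3.3-fold higher number from compound 1 to compound 2 (0.52 log units; beyond the scatter) shows that exchanging fluoro for bromo there raised the number beyond the scatter, while the step of a 1.2-fold higher number from compound 2 to compound 3 (0.08 log units; within the scatter) shows that the added fluoro changed little. Going by the values given here, no measured compound carries a methoxy group at this position, so the new group itself is untested. Since the bromo is removed, and compound 1 without bromo gave 290 nM, a lower number than compound 3 is expected for compound 4, though not with confidence; the expected step is a 1.9-fold lower number from compound 3 to compound 4 (0.28 log units; within the scatter). Compound 4 is estimated at 600 nM, within a range of 200 nM to 1800 nM.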

Compound 4, half-maximal inhibitory concentration: 4150 nM
The estimate for compound 4 lay 6.9-fold (0.84 log units) below the measured number, outside the stated range (above it).
By their numbers in this assay, from the lowest: compound 1; then compounds 2 and 3 (each within the scatter of the next); then compound 4.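

Taking the bromo away did not bring the number back towards compound 1, as the earlier compounds had suggested it might: changing to 4-methoxyphenyl gave a 3.6-fold higher number from compound 3 to compound 4 (0.56 log units; beyond the scatter) in this assay, and methoxy in place of bromo alone gave a 4.4-fold higher number from compound 2 to compound 4 (0.64 log units; beyond the scatter). Bromo is therefore not the only group at this position that goes with a higher number, and the widest step seen here is methoxy in place of fluoro, a 14-fold higher number from compound 1 to compound 4 (1.16 log units; beyond the scatter), which places the fluoro compound lowest, the two bromo compounds in the middle and the methoxy compound highest across these four compounds. No measurement among the data shown accounts for this order or connects it to any property of the groups.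

Going by these compounds, it remains open where a hydrogen, chloro, hydroxy, ethoxy or dimethylamino group in place of the methoxy would fall in this order, and so whether the rise belongs to methoxy alone or extends to other groups. On these data alone, it is also open whether an added fluoro, which changed little with bromo present, would change little with methoxy present.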